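Bromoalkoxy chain length on the shared core

This account rests on a few compounds, and the source may have more. Where it says the series, first, only, none or still open, it means among the compounds named here.

Compound 1 `CCOc1ccc2c(=O)c(-c3ccc(O)cc3)coc2c1` gives 40 nM in an assay on isolated protein (Cricetulus griseus) for inhibition of aldehyde dehydrogenase, mitochondrial (Homo sapiens); a lower number here means a stronger inhibitor, a higher number a weaker inhibitor.
Compound 2 `O=c1c(-c2ccc(O)cc2)coc2cc(OCCCCCCBr)ccc12` gives 300 nM in this assay .

Within the data shown here, compound 2 holds the highest of the two numbers; its only neighbour is compound 1, reached through the single measured step of a 7.5-fold higher number from compound 1 to compound 2 (0.88 log units; beyond the scatter). Compound 3 `O=c1c(-c2ccc(O)cc2)coc2cc(OCCCCBr)ccc12` differs from compound 2 by bromo in place of 2-bromoethyl on a saturated chain carbon, four bonds along the chain from an oxygen on an aromatic ring, shortening the chain part of the way back toward compound 1 while keeping the bromine. Among the measured compounds shown here, the one step on record points downward when the chain is shortened, so a modest fall is expected, smaller than that step. The expected step is a 2.0-fold lower number from compound 2 to compound 3 (0.30 log units; within the scatter). Compound 3 is therefore estimated at 150 nM, within 50 nM to 450 nM.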

Compound 3, half-maximal inhibitory concentration: 270 nM
For compound 3 the middle estimate is 1.8-fold (0.26 log units) below the measured one; the measured number falls inside the stated range.
By their numbers in this assay, from the lowest: compound 1; then compounds 3 and 2 (each within the scatter of the next).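

In this assay, bromo in place of 2-bromoethyl gives a 1.1-fold lower number from compound 2 to compound 3 (0.05 log units; within the scatter), so this change in chain length does not separate compound 2 from compound 3. With 2-bromoethyl in place of hydrogen, two bonds along the chain from an oxygen on an aromatic ring, the result is a 6.8-fold higher number from compound 1 to compound 3 (0.83 log units; beyond the scatter), so the shorter bromine-bearing chain also stands clear of compound 1. No supporting data bear on this result. Still open, on these data alone, is whether a chain of the same length without bromine, or with an amine or a carboxylic acid at its end, would behave similarly.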